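Hydroxyacyl variation on the shared core: permeability notes

The compounds below may be only part of what the source reports. "The series", "measured", "known", "first", "only" and "open" are said of these compounds alone.

Two members of the series carry a number in an ADME assay on Caco-2 cells (Homo sapiens) for permeability, read by LC-MS, in the apical to basolateral direction, with a stated time of 60 min, at pH 6.5; on this read-out lower numbers stand for lower permeability and higher numbers for higher permeability. Compound 1 `O=C(NCc1cc(Cl)ccc1-n1cnnn1)[C@@H]1C[C@@H]2C[C@@H]2N1C(=O)[C@H](O)c1ccccc1F` gives 16 10^-6 cm/s in this assay, the lower of the two values seen so far. Compound 2 `CCCC[C@@H](O)C(=O)N1C[C@H]2C[C@H]2[C@H]1C(=O)NCc1cc(Cl)ccc1-n1cnnn1` gives 33 10^-6 cm/s in this assay, a higher number that lies beyond the scatter of the read-out. Compound 3 `CC(C)(C)[C@@H](O)C(=O)N1[C@H](C(=O)NCc2cc(Cl)ccc2-n2cnnn2)C[C@@H]2C[C@@H]21` has not yet been measured in this assay. It differs from compound 1 in one place: tert-butyl in place of 2-fluorophenyl on a saturated chain carbon bound to a carbonyl carbon and an oxygen on a saturated carbon. Among the compounds with values here, no measured pair of the series shows exactly this change, so the expectation rests on compound 1 alone, with compound 2 as the only other point of reference for a change at the same carbon. A modest upward step, a 1.6-fold higher number from compound 1 to compound 3 (0.21 log units; within the scatter), is expected, close to the edge of the scatter. For compound 3 the estimated value in this assay is 26 10^-6 cm/s, with a range from 13 10^-6 cm/s to 50 10^-6 cm/s.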

Compound 3, apparent permeability: 16 10^-6 cm/s
For compound 3 the middle estimate is 1.6-fold (0.21 log units) above the measured one; the range from low to high includes it.
By their numbers in this assay, from the lowest: compounds 1 and 3 (each within the scatter of the next); then compound 2.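

In this assay, tert-butyl in place of 2-fluorophenyl on a saturated chain carbon bound to a carbonyl carbon and an oxygen on a saturated carbon gives no change at the digits printed from compound 1 to compound 3 (within the scatter). At this carbon, therefore, the read-out does not depend on the six-membered aromatic ring: a group with no ring and fewer heavy atoms takes its place with no step beyond the scatter. No measurement at hand offers an explanation for this result.

Compound 2 differs from compound 1 and compound 3 in more than one place, so its value cannot be assigned to this carbon alone. Still open, as far as these compounds go, is how an amine, a carboxylic acid or a longer chain at this carbon on the shared core would read in this assay.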